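Swapping a Hydroxy Group for Two Alkoxy Groups

The source may hold more compounds than are shown below. What is called first, only, known or untested is meant among the compounds shown, and "the series" means these compounds.

Three measured compounds share one core and differ only in the aryl group on a carbon with a double bond to nitrogen. Compound 1 `CCCCc1oc2ccc(/N=C/c3ccc(O)cc3)cc2c1C(=O)c1ccc(OC)cc1` carries a 4-hydroxyphenyl there, and in a functional assay, with a stated time of 30 min (on this read-out higher numbers stand for weaker inhibition and lower numbers for stronger inhibition), compound 1 gives 22.8 ug/mL. Compound 2 `CCCCc1oc2ccc(/N=C/c3ccc(OC)cc3OC)cc2c1C(=O)c1ccc(OC)cc1` carries a 2,4-dimethoxyphenyl and gives 20.5 ug/mL, while compound 3 `CCCCc1oc2ccc(/N=C/c3ccccc3)cc2c1C(=O)c1ccc(OC)cc1` carries a phenyl and gives 34.2 ug/mL. Compound 1 thus stands second highest of the three, with compound 2 nearest and compound 3 furthest, yet both steps, a 1.1-fold lower number from compound 1 to compound 2 (0.05 log units; within the scatter) and a 1.5-fold higher number from compound 1 to compound 3 (0.18 log units; within the scatter), stay within the scatter, as does a 1.7-fold higher number from compound 2 to compound 3 (0.22 log units; within the scatter).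

Compound 4 `CCCCc1oc2ccc(/N=C/c3ccc(OCC)c(OC)c3)cc2c1C(=O)c1ccc(OC)cc1` has not yet been measured. It differs from compound 1 in one place: 4-ethoxy-3-methoxyphenyl in place of 4-hydroxyphenyl on a carbon with a double bond to nitrogen. Among the measured compounds shown here, the closest precedent is a 1.1-fold lower number from compound 1 to compound 2 (0.05 log units; within the scatter), which also exchanged the hydroxy for methoxy groups and was small. No step beyond the scatter is therefore expected in this assay. Compound 4 is expected to give 20 ug/mL, between 12 ug/mL and 34 ug/mL, which means a 1.1-fold lower number from compound 1 to compound 4 (0.06 log units; within the scatter).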

Compound 4, half-maximal inhibitory concentration: 14.8 ug/mL
For compound 4 the middle estimate is 1.4-fold (0.13 log units) above the measured one; the measured number falls inside the stated range.
By their numbers in this assay, from the lowest: compounds 4, 2, 1 and 3 (each within the scatter of the next, the first and the last beyond it).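

In this assay this position gives its first step beyond the scatter: 4-ethoxy-3-methoxyphenyl in place of plain phenyl produces a 2.3-fold lower number from compound 3 to compound 4 (0.36 log units; beyond the scatter) and so separates two groups on the same core. Against the aryl groups that already carry oxygen, the change stays within the scatter, with a 1.5-fold lower number from compound 1 to compound 4 (0.19 log units; within the scatter) and a 1.4-fold lower number from compound 2 to compound 4 (0.14 log units; within the scatter) leaving compound 1, compound 2 and compound 4 without a rank order. No measurement shown here accounts for the gap between phenyl and 4-ethoxy-3-methoxyphenyl.

The compounds shown do not separate what the ethoxy and the methoxy of compound 4 each contribute. They also leave open whether a longer chain such as butoxy in place of the ethoxy, or an amine on this aryl ring, would move the number beyond the scatter relative to compound 1.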